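Methyl to Trifluoromethyl on the Urea Aryl Ring

The compounds below may be only part of what the source reports. "The series", "measured", "known", "first", "only" and "open" are said of these compounds alone.

Measured compounds:
compound 1, `COc1cc2cc(Oc3ccc(NC(=O)Nc4ccccc4)cc3)c(C)nc2cc1OC`, 37.9%
compound 2, `COc1cc2cc(Oc3ccc(NC(=O)Nc4ccc(C)cc4)cc3)c(C)nc2cc1OC`, 82.4%

In a functional assay on MOLT-4 cells (Homo sapiens) for inhibition, read by sulforhodamine B assay, with a stated time of 48 h, tested at 10 uM (on this read-out higher numbers stand for a weaker effect at the one concentration tested and lower numbers for a stronger effect), compound 2 gives the higher of the two numbers, the weaker effect. Among the compounds with values here, the only step measured is a number 44.5 percentage points higher from compound 1 to compound 2 (beyond the scatter), which came with trifluoromethyl in place of methyl on an aromatic carbon being not yet the change at hand; that earlier step put methyl in place of hydrogen on the same aromatic carbon. Compound 3, `COc1cc2cc(Oc3ccc(NC(=O)Nc4ccc(C(F)(F)F)cc4)cc3)c(C)nc2cc1OC`, differs from compound 2 by trifluoromethyl in place of methyl on an aromatic carbon. No measured step covers an exchange of methyl for trifluoromethyl, so the one step shown bears on it only in that substitution at this carbon has already moved the number strongly once. With no closer guide, the estimated step is a number 7.4 percentage points lower from compound 2 to compound 3 (within the scatter), expected to be small and within the scatter. Compound 3 is therefore estimated at 75%, between 45% and 100%.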

Compound 3, a percentage reported as activity, at one concentration (the size of the read-out at that concentration, not a potency): 61.9%
Estimate against measurement, compound 3: 13.1 percentage points above; low and high end bracket the measured number.
By their numbers in this assay, from the lowest: compound 1; then compound 3; then compound 2.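

In this assay, the exchange of methyl for trifluoromethyl on this aromatic carbon gives a number 20.5 percentage points lower from compound 2 to compound 3 (beyond the scatter), a stronger effect, so the loss seen on substitution depends on which group sits there and not only on the carbon being substituted. Set against hydrogen, trifluoromethyl still gives a number 24 percentage points higher from compound 1 to compound 3 (beyond the scatter), a weaker effect, so among these three compounds both substituents fall short of hydrogen, and no compound shown goes against this. Nothing available explains why trifluoromethyl and methyl differ at this carbon.

The compounds shown leave open whether a chlorine, a methoxy group or an amine on this carbon would match or pass hydrogen. They also leave open whether trifluoromethyl would act the same way on another carbon of this ring.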